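Replacing 4-ethylcyclohexyl with 2-methoxyphenyl

A few compounds are considered here, and "the series" means these few. Any claim that something is new, unique, unknown or untested is made for them only; others in the source may bear on it.

In an ADME assay on MDBK cells (Bos taurus) for cytotoxicity, read by MTT assay (on this read-out higher numbers stand for lower toxicity in this test and lower numbers for higher toxicity in this test), compound 1 (`CCC1CCC(OCCCCCCN2C[C@H](O)[C@@H](O)[C@H](O)[C@H]2CO)CC1`) gives > 500000 nM as a limit of the assay and not a number. Compound 1 therefore sits at the limit of > 500000 nM in this assay, at which 1 of the 2 values shown sits, in this small set. Among the measured compounds shown here, compound 2 (`CCCCC1CCC(OCCCCCCN2C[C@H](O)[C@@H](O)[C@H](O)[C@H]2CO)CC1`) gives 190000 nM as a true number in this assay and is the only other measured compound. Compound 3 (`COc1ccccc1OCCCCCCN1C[C@H](O)[C@@H](O)[C@H](O)[C@H]1CO`) differs from compound 1 by 2-methoxyphenyl in place of 4-ethylcyclohexyl on an oxygen on a saturated carbon and this is a change of a different kind from the ethyl in place of hydrogen on a saturated chain carbon that leads to compound 2. With only an at least 2.6-fold lower number from compound 1 to compound 2 (0.42 log units; beyond the scatter) as a loose guide, a modest move towards a lower number in this assay is expected, possibly none beyond the scatter. The expected change is an at least 1.6-fold lower number from compound 1 to compound 3 (0.22 log units; that floor lies within the scatter) as a rough estimate. Compound 3 is estimated at 300000 nM with a range from 110000 nM to 500000 nM as its upper end.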

Compound 3, half-maximal cytotoxic concentration: > 500000 nM
Compound 3 gave a limit, no number (the forecaster's own chance of this, stated with the estimate: 40%); middle value at least 1.6-fold (0.22 log units) away from the limit.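

Compound 1 and compound 3 both give a limit of the assay and not a number, so no step can be read between them: the limit of > 500000 nM in this assay, at which 2 of the 3 values shown sit.

The compounds shown leave open whether 2-methoxyphenyl and 4-ethylcyclohexyl differ at all in this assay.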